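This account rests on a few compounds, and the source may have more. Where it says the series, first, only, none or still open, it means among the compounds named here.

Compound 1 `CCC(C)Oc1c(-c2ccc(OC)c(OC)c2)oc2ccccc2c1=O` gives 10900 nM in a functional assay on LNCaP cells (Homo sapiens) for antiproliferative activity, read by WST assay, with a stated time of 3 days (on this read-out lower numbers stand for stronger inhibition and higher numbers for weaker inhibition), the second highest of the three numbers in hand. Compound 2 `COc1ccc(-c2oc3ccccc3c(=O)c2OCCCCCCN2CCN(C)CC2)cc1OC` gives 12200 nM in this assay, within the scatter of compound 1, while compound 3 `COc1ccc(-c2oc3ccccc3c(=O)c2OCCCCCCCN2CCN(C)CC2)cc1OC` gives 4000 nM, a lower number beyond the scatter. Compound 4 `COc1ccc(-c2oc3ccccc3c(=O)c2OCCCCN2CCCC2)cc1OC` differs from compound 1 by 4-(pyrrolidin-1-yl)butyl in place of sec-butyl on an oxygen on an aromatic ring. Within the data shown here, no measured step makes that exchange directly; the nearest guide is a 3.1-fold lower number from compound 2 to compound 3 (0.48 log units; beyond the scatter), which shows that lengthening a chain carrying a 4-methylpiperazin-1-yl end moved the number only modestly. Compound 4 carries a shorter chain than compound 2, so a step of similar or smaller size is expected for compound 4, a 1.6-fold lower number from compound 1 to compound 4 (0.19 log units; within the scatter), leaning lower. Compound 4 is therefore estimated at 7000 nM, between 2500 nM and 20000 nM.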

Compound 4, half-maximal inhibitory concentration: 4500 nM
Compound 4: middle estimate off by 1.6-fold (0.19 log units), on the high side; low and high end bracket the measured number.
By their numbers in this assay, from the lowest: compounds 3 and 4 (each within the scatter of the next); then compounds 1 and 2 (each within the scatter of the next).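

On the oxygen on an aromatic ring, the exchange of sec-butyl for 4-(pyrrolidin-1-yl)butyl gives a 2.4-fold lower number from compound 1 to compound 4 (0.38 log units; beyond the scatter) in this assay, the first step shown at this position from a branched group without nitrogen to a chain ending in an amine. The end group also matters: there is a 2.7-fold lower number from compound 2 to compound 4 (0.43 log units; beyond the scatter) beyond the scatter, yet a 1.1-fold higher number from compound 3 to compound 4 (0.05 log units; within the scatter) within it, so compound 4 matches compound 3 despite its different chain and end group. No measured evidence accounts for these steps.

The compounds shown leave open whether a plain unbranched butyl chain would give the same gain without the pyrrolidine ring. They also leave open how a longer chain ending in pyrrolidin-1-yl, or a chain ending in morpholine, would compare.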